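This account rests on a few compounds, and the source may have more. Where it says the series, first, only, none or still open, it means among the compounds named here.

Measured in a functional assay on MDA-MB-231 cells (Homo sapiens) for inhibition, read by MTT assay, with a stated time of 72 h; on this read-out higher numbers stand for weaker inhibition and lower numbers for stronger inhibition:
compound 1 `O=C(CSc1nc(Nc2ccccc2)c2ccccc2n1)Nc1cccc(Br)c1` gives 17500 nM
compound 2 `O=C(CSc1nc(Nc2ccccc2)c2ccccc2n1)Nc1ccc(F)c(Cl)c1` gives 21600 nM
compound 3 `C=CC(=O)Nc1cccc(NC(=O)CSc2nc(Nc3ccccc3C)c3ccccc3n2)c1` gives 20400 nM

All three numbers lie within the scatter of one another, so compound 3 sits in the same band as compound 1 and compound 2, with no ordering among them that the data support.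

Compound 4 `C=CC(=O)Nc1cccc(NC(=O)CSc2nc(Nc3cc(OC)c(OC)c(OC)c3)c3ccccc3n2)c1` is not yet measured. Its change from compound 3: 3,4,5-trimethoxyphenyl in place of 2-methylphenyl on a nitrogen on an aromatic ring

Among the measured compounds shown here, the one measured step, a 1.2-fold higher number from compound 1 to compound 2 (0.09 log units; within the scatter), concerns a group on an amide-type nitrogen, a different place from the one changed here, and was within the scatter. Nothing measured speaks to the 3,4,5-trimethoxyphenyl group. No step beyond the scatter is therefore expected in this assay.

Compound 4 is expected at 20000 nM, with a range of 7000 nM to 55000 nM.

That estimate means an expected step of a 1.0-fold lower number from compound 3 to compound 4 (0.01 log units; within the scatter).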

Compound 4, half-maximal inhibitory concentration: > 50000 nM
Compound 4: no number, only a limit; the forecaster's own chance of this, stated with the estimate: 10%; at least 2.5-fold (0.39 log units) between middle value and limit.
By their numbers in this assay, from the lowest: compounds 1, 3 and 2 (each within the scatter of the next). At a limit, above all of these: compound 4.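

Among the compounds shown here, the nitrogen on an aromatic ring is the first place where a change reads beyond the scatter: 3,4,5-trimethoxyphenyl in place of 2-methylphenyl gives an at least 2.4-fold higher number from compound 3 to compound 4 (0.38 log units; beyond the scatter) in this assay. Going by these compounds, for compound 4 the read-out is a limit of the assay and not a number, so the true size of this step stays unknown: the limit of > 50000 nM in this assay, at which 1 of the 4 values shown sits.

Open, on these data alone, is whether a single methoxy group on that phenyl ring gives the same step. Also open, as far as these compounds go, is how an amine or a carboxylic acid at this place would read.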